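This account rests on a few compounds, and the source may have more. Where it says the series, first, only, none or still open, it means among the compounds named here.

Measured so far:
Compound 1, `CSc1nc(-c2ccccc2)c(C#N)c(N2CCN(c3ccnc4cc(Cl)ccc34)CC2)n1` — in an ADME assay on MDCK cells (Canis lupus familiaris) for cytotoxicity, read by microscopy (a higher number here means that more compound is tolerated, a lower number that less compound is tolerated), compound 1 gives > 100000 nM, a limit of the assay.
Compound 2, `CSc1nc(NCCCCNc2ccnc3cc(Cl)ccc23)c(C#N)c(-c2cccc([N+](=O)[O-])c2)n1` — in this assay compound 2 gives 20000 nM.

Going by the values given here, compound 2 holds the only actual number in this assay; the other value is a limit. Compound 1 sits at the limit of > 100000 nM in this assay, at which 1 of the 2 values shown sits. Compound 3, `COc1ccc(-c2nc(SC)nc(NCCCCNc3ccnc4cc(Cl)ccc34)c2C#N)cc1`, differs from compound 2 in one place: 4-methoxyphenyl in place of 3-nitrophenyl on an aromatic carbon. Among the compounds with values here, no measured step covers this change, so the account rests on compound 2 alone. From compound 2 a step of a 1.5-fold higher number from compound 2 to compound 3 (0.18 log units; within the scatter) is expected, not beyond the usual scatter. Compound 3 is therefore estimated at 30000 nM, within 10000 nM to 100000 nM.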

Compound 3, minimum cytotoxic concentration: 20000 nM
Compound 3: the middle estimate sits 1.5-fold (0.18 log units) above what was measured; low and high end bracket the measured number.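

Replacing 3-nitrophenyl with 4-methoxyphenyl on this aromatic carbon, next to the ring nitrogen, gives no change at the digits printed from compound 2 to compound 3 (within the scatter) in this assay. Going by these compounds alone, this is the first step read at this position, and it shows that these two substituted phenyl groups can be exchanged here without a shift beyond the scatter. Nothing measured here bears on why this is so.

Still open, going by these compounds, is whether an amine or a carboxylic acid on this phenyl ring, or an unsubstituted phenyl at this position, would behave the same way.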